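Amide substituent variation on a naphthol inhibitor series

The source may hold more compounds than are shown below. What is called first, only, known or untested is meant among the compounds shown, and "the series" means these compounds.

Measured so far:
- compound 1, `O=C(c1c(O)ccc2cc(-c3cccc(O)c3)ccc12)N1CCOCC1`: 28%
- compound 2, `CNC(=O)c1c(O)ccc2cc(-c3cccc(O)c3)ccc12`: 22%
- compound 3, `O=S(=O)(c1ccccc1)c1c(O)ccc2cc(-c3cccc(O)c3)ccc12`: "not determined" (no result reported)

In an in vitro assay on Sf9 cells for inhibition of 17-beta-hydroxysteroid dehydrogenase type 1 (Homo sapiens), tested at 100 nM (on this read-out higher numbers stand for a stronger effect at the one concentration tested and lower numbers for a weaker effect), compound 1 gives 28%, and compound 2 gives 22%. Compound 2 stands as the lower of the two numbers, but the step of a number 6 percentage points lower from compound 1 to compound 2 (within the scatter) lies within the scatter, so the two cannot be told apart. Compound 3, with a sulfonyl group instead of the amide, gives "not determined" (no result reported) in this assay.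

The new compound 4, `O=C(Nc1cccc(O)c1)c1c(O)ccc2cc(-c3cccc(O)c3)ccc12`, differs from compound 2 as follows: 3-hydroxyphenyl in place of methyl on an amide-type nitrogen. Within the data shown here, no measured step touches this amide nitrogen; the only step known, from a morpholine to a methylamino amide, was within the scatter, which gives little guidance on the size of the effect of the present change. A small shift in either direction, or none beyond the scatter, is therefore the expectation. Compound 4 is estimated at 35% in this assay, within 10% to 65%. The expected step of a number 13 percentage points higher from compound 2 to compound 4 (beyond the scatter) is accordingly modest.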

Compound 4, a percentage reported as inhibition, at one concentration (the size of the read-out at that concentration, not a potency): 21%
Beside the measured number, compound 4's estimate is 14 percentage points above it, and the stated range covers the measured number.
By their numbers in this assay, from the lowest: compounds 4, 2 and 1 (each within the scatter of the next).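

In this assay, 3-hydroxyphenyl in place of methyl on the amide-type nitrogen gives a number 1 percentage points lower from compound 2 to compound 4 (within the scatter) and so adds a six-membered aromatic ring with a hydroxyl group at this position without a difference that can be read. (3-Hydroxyphenyl)amino in place of morpholin-4-yl on the carbonyl carbon gives a number 7 percentage points lower from compound 1 to compound 4 (within the scatter) and so is no more separable, which leaves the morpholine, methylamino and (3-hydroxyphenyl)amino amides indistinguishable at the one concentration tested. No independent evidence bears on this result.

On these data alone, it remains open whether a longer alkyl chain, a chain ending in a carboxylic acid or one ending in a dimethylamino group on the amide nitrogen would give a step beyond the scatter. As far as these compounds go, it is also open how an ester in place of the amide would read.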